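An aromatic group in place of a branched chain

This account rests on a few compounds, and the source may have more. Where it says the series, first, only, none or still open, it means among the compounds named here.

Going by the values given here, compound 1 `C#CC(=O)N1C(C(CC)CCCC)SC[C@@H]1C(=O)OCC` gives 1600 nM in a functional assay on MV cells (Homo sapiens) for inhibition, read by sulforhodamine B assay (a higher number here means a weaker inhibitor, a lower number a stronger inhibitor), the highest of the two numbers so far, with compound 2 `C#CC(=O)N1C(C(C)(C)C)SC[C@@H]1C(=O)OCC` nearest at 900 nM. Among the compounds with values here, the only measured step, a 1.8-fold lower number from compound 1 to compound 2 (0.25 log units; within the scatter), exchanged one saturated group for another and stayed within the scatter. Compound 3 `C#CC(=O)N1C(c2ccc(F)cc2)SC[C@@H]1C(=O)OCC` carries 4-fluorophenyl in place of 1-ethylpentyl on a saturated ring carbon. Within the data shown here, no measured step bears directly on such a change, and the one step available offers no direction. The estimated step of a 1.5-fold lower number from compound 1 to compound 3 (0.16 log units; within the scatter) is therefore expected to be small, with no direction beyond the scatter. Compound 3 is estimated at 1100 nM, with a range from 400 nM to 3000 nM.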

Compound 3, half-maximal inhibitory concentration: 400 nM
Compound 3: the middle estimate sits 2.8-fold (0.44 log units) above what was measured; low and high end bracket the measured number.
By their numbers in this assay, from the lowest: compound 3; then compounds 2 and 1 (each within the scatter of the next).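

On the saturated ring carbon next to the ring nitrogen and the ring sulfur, this change moves the number beyond the scatter: 4-fluorophenyl in place of 1-ethylpentyl gives a 4.0-fold lower number from compound 1 to compound 3 (0.60 log units; beyond the scatter), and 4-fluorophenyl in place of tert-butyl gives a 2.3-fold lower number from compound 2 to compound 3 (0.35 log units; beyond the scatter). Going by these compounds alone, the exchange between the two saturated groups had stayed within the scatter, so this is the first clear difference at this position. Nothing available explains the difference.

As far as these compounds go, it remains open whether a plain phenyl or a cyclohexyl group at this carbon would give a number like that of compound 3. From the compounds shown here alone, whether the fluorine contributes at all also remains open.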